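Aryl swap on the amine side of a sulfonamide series

The source may hold more compounds than are shown below. What is called first, only, known or untested is meant among the compounds shown, and "the series" means these compounds.

Measured compounds:
compound 1, `O=S(=O)(NCCCCNCc1ccc(Br)cc1)c1cc(C(F)(F)F)cc(C(F)(F)F)c1`: 2000 nM
compound 2, `O=S(=O)(NCCCNCc1cccc2ccccc12)c1cc(C(F)(F)F)cc(C(F)(F)F)c1`: 2400 nM

Both values come from a functional assay on HPAC cells (Homo sapiens) for inhibition, read by MTT assay, with a stated time of 72 h; on this read-out higher numbers stand for weaker inhibition of growth and lower numbers for stronger inhibition of growth. On these two numbers compound 2 and compound 1 sit within the usual scatter of each other, so neither is separated from the other. Compound 3, `COc1ccc(CNCCCNS(=O)(=O)c2cc(C(F)(F)F)cc(C(F)(F)F)c2)cc1`, carries 4-methoxyphenyl in place of naphthalen-1-yl on a saturated chain carbon bound to an amine nitrogen. Among the measured compounds shown here, no measured pair in the set shares this change, so nothing shows its size or direction. The expected step is none beyond the scatter, estimated as a 1.0-fold higher number from compound 2 to compound 3 (0.02 log units; within the scatter). For compound 3 the estimated value in this assay is 2500 nM, with a range from 800 nM to 8000 nM.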

Compound 3, concentration for 50% growth inhibition: 3000 nM
Beside the measured number, compound 3's estimate is 1.2-fold (0.08 log units) below it; the measured number falls inside the stated range.
By their numbers in this assay, from the lowest: compounds 1, 2 and 3 (each within the scatter of the next).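

On the amine side, 4-methoxyphenyl in place of naphthalen-1-yl gives a 1.3-fold higher number from compound 2 to compound 3 (0.10 log units; within the scatter) in this assay, so this first single-group change at this position stays within the scatter. The wider change gives a 1.5-fold higher number from compound 1 to compound 3 (0.18 log units; within the scatter), also within the scatter, though it alters the chain together with the aryl group and does not separate the two. No measurement on hand gives a cause for either step.

Going by these compounds, whether any replacement here can move the number beyond the scatter stays open. A carboxylic acid or a primary amine in place of 4-methoxyphenyl would test this.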